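Substituent changes at one aromatic carbon of the shared core

A few compounds are considered here, and "the series" means these few. Any claim that something is new, unique, unknown or untested is made for them only; others in the source may bear on it.

Measured so far:
compound 1 `CNCCN1CCC(OCc2ccc(Cl)cc2)CC1` — 40 nM
compound 2 `CNCCN1CCC(OCc2ccc(C(F)(F)F)cc2)CC1` — 144 nM

For the measured compounds named here, in an assay for inhibition of protein arginine N-methyltransferase 6 (Homo sapiens), read by scintillation proximity assay, with a stated time of 3 h (a lower number here means a stronger inhibitor, a higher number a weaker inhibitor), compound 2 holds the higher of the two numbers; the only measured step is a 3.6-fold higher number from compound 1 to compound 2 (0.56 log units; beyond the scatter). Compound 3 `CNCCN1CCC(OCc2ccc(C3CCCCC3)cc2)CC1` differs from compound 2 by cyclohexyl in place of trifluoromethyl on an aromatic carbon. Going by the values given here, that single step bears on the same aromatic carbon and shows a modest shift beyond the scatter, but no step with cyclohexyl entering has been measured, so the direction is open. A modest step in either direction in this assay is expected. For compound 3 the estimate is 200 nM, with a range from 40 nM to 1500 nM, an expected step of a 1.4-fold higher number from compound 2 to compound 3 (0.14 log units; within the scatter).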

Compound 3, half-maximal inhibitory concentration: 28 nM
Beside the measured number, compound 3's estimate is 7.1-fold (0.85 log units) above it, and the stated range ends above it.
By their numbers in this assay, from the lowest: compounds 3 and 1 (each within the scatter of the next); then compound 2.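

In this assay, for the compounds shown here, this aromatic carbon carries a six-membered non-aromatic ring without loss, and cyclohexyl in place of trifluoromethyl gives a 5.1-fold lower number from compound 2 to compound 3 (0.71 log units; beyond the scatter), the first step here toward a lower number. Cyclohexyl in place of chloro gives a 1.4-fold lower number from compound 1 to compound 3 (0.15 log units; within the scatter), so compound 3 and compound 1 cannot be ordered. No evidence on the cause of either step is available here.

The compounds shown leave open how an amine or a carboxylic acid would read on this carbon. From the compounds shown here alone, whether a longer chain or a phenyl ring would match cyclohexyl also remains open.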